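The compounds below may be only part of what the source reports. "The series", "measured", "known", "first", "only" and "open" are said of these compounds alone.

Measured compounds:
- compound 1 `Cc1nn2c(O)cc(C3CCOCC3)nc2c1Cc1cccc(C(F)(F)F)c1C`: 3.98 nM
- compound 2 `CCc1nn2c(O)cc(C3CCOCC3)nc2c1Cc1cccc(Cl)c1Cl`: 12.6 nM
- compound 3 `COc1nn2c(O)cc(-c3ccncc3)nc2c1Cc1cccc(Cl)c1Cl`: 1.26 nM

Of the compounds shown here, three built on a shared core have been tested in an assay on isolated protein for inhibition of phosphatidylinositol 4,5-bisphosphate 3-kinase catalytic subunit beta isoform (Homo sapiens); a higher number here means a weaker inhibitor, a lower number a stronger inhibitor. Compound 1 gives 3.98 nM in this assay, which places it second highest of the three numbers. Compound 3 gives 1.26 nM, a lower number than compound 1 by a gap that lies beyond the scatter, while compound 2 gives 12.6 nM, a higher number than compound 1, again beyond the scatter. Compounds 2 and 3 differ from compound 1 in several places at once, so no single structural step can be read from them.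

The compound still to be measured is compound 4 `Cc1nn2c(NCCO)cc(C3CCOCC3)nc2c1Cc1cccc(C(F)(F)F)c1C`. It differs from compound 1 in one place: (2-hydroxyethyl)amino in place of hydroxy on an aromatic carbon. The core, the oxan-4-yl group and the substituted benzyl arm are unchanged. Among the compounds with values here, no measured pair shows this change, so the expectation rests on compound 1 alone. The hydroxy at this position is exchanged for a longer (2-hydroxyethyl)amino chain, and a small step toward a higher number, close to the scatter, is expected for compound 4, namely a 2.0-fold higher number from compound 1 to compound 4 (0.30 log units; within the scatter). Compound 4 is therefore estimated at 8 nM in this assay, with a range from 2 nM to 35 nM.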

Compound 4, half-maximal inhibitory concentration: 1260 nM
Beside the measured number, compound 4's estimate is 160-fold (2.20 log units) below it, outside the stated range (above it).
By their numbers in this assay, from the lowest: compound 3; then compound 1; then compound 2; then compound 4.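

In this assay, within the data shown here, the exchange of hydroxy for (2-hydroxyethyl)amino, on the aromatic carbon next to the ring nitrogen, gives a 320-fold higher number from compound 1 to compound 4 (2.50 log units; beyond the scatter) and is the first change seen at this position. All three earlier compounds carry hydroxy here and differ from one another only elsewhere, so they could not show whether this position matters; this single step shows that the number depends strongly on what sits there, at least with the oxan-4-yl group and the benzyl arm of compound 1 in place. No measurement at hand explains why the number rises so far.

The compounds shown leave open whether the rise comes with any replacement of hydroxy or with this particular chain, since a plain amino group, a methoxy group or a methylamino group at the same carbon would separate the nitrogen from the chain and its terminal hydroxy. They also leave open whether the same exchange has a step of similar size on compounds carrying the other groups of compound 2 or compound 3.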